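The source may hold more compounds than are shown below. What is called first, only, known or untested is meant among the compounds shown, and "the series" means these compounds.

Measured so far in a functional assay on the whole organism (stomach) with Rattus norvegicus as the target; on this read-out higher numbers stand for an effect only at larger amounts of compound and lower numbers for an effect already at smaller amounts:
compound 1, `C/N=C(/S)CCCCCn1nc(-c2ccccc2)ccc1=O`, gives 25.2 mg/kg.
compound 2, `N=C(S)CCCCn1nc(-c2ccccc2)ccc1=O`, gives > 100 mg/kg, which is a limit of the assay and not a number.

Going by the values given here, the only measured step is an at least 3.9-fold higher number from compound 1 to compound 2 (0.59 log units; beyond the scatter), a change at the far end of the chain carrying the thioamide. It ends at the limit of > 100 mg/kg in this assay, at which 1 of the 2 values shown sits, so compound 2 stands at the edge of what this assay can report, with no number of its own.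

Compound 3, `O=c1ccc(-c2ccccc2)nn1CCC(=S)N1CCCC1`, differs from compound 2 by a group of 7 heavy atoms (5 carbon, 1 nitrogen, 1 sulfur; one five-membered non-aromatic ring with 1 hetero atom) in place of a group of 5 heavy atoms (3 carbon, 1 nitrogen, 1 sulfur; no ring), on a saturated chain carbon, two bonds along the chain from an aromatic nitrogen. Among the compounds with values here, no measured step covers a ring on the thioamide nitrogen, nor a chain of this shorter length, so the direction of the change in this assay is open. Because compound 2 sits at the limit, any number for compound 3 would already be a move toward smaller doses. Compound 3 is therefore estimated at about 60 mg/kg, in a range from 25 mg/kg to 150 mg/kg, which means an expected step of an at least 1.6-fold lower number from compound 2 to compound 3 (0.22 log units; that floor lies within the scatter), with a real chance that again only a limit is reported.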

Compound 3, dose for half-maximal effect: > 100 mg/kg
Compound 3: only a limit was reported; the forecaster's own chance of this, stated with the estimate: 45%; at least 1.6-fold (0.22 log units) between middle value and limit.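

In this assay compound 3 gives > 100 mg/kg, a limit of the assay and not a number. Set against the only compound here with a number, the result is an at least 3.9-fold higher number from compound 1 to compound 3 (0.59 log units; beyond the scatter), so the five-membered ring on the thioamide nitrogen, on a saturated chain carbon two bonds along the chain from an aromatic nitrogen, does not bring back a dose that can be read. The step between compound 2 and compound 3 cannot be read, even though the group that leaves counts 2 hydrogen-bond donors and the group that enters counts 0, so the two groups cannot be ranked against each other, because both compounds stop at the same ceiling: the limit of > 100 mg/kg in this assay, at which 2 of the 3 values shown sit.

The compounds shown do not tell whether the length of the chain or the group on the thioamide nitrogen matters more for the number seen with compound 1. A longer chain ending in the same five-membered ring, or an ethyl group in place of the methyl group on the thioamide nitrogen of compound 1, would help to separate these two influences.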